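The compounds below may be only part of what the source reports. "The series", "measured", "known", "first", "only" and "open" are said of these compounds alone.

Measured compounds:
Compound 2, `CCCCNc1nc(N)nc2c1ncn2/C=C1/CC1(CO)CO`: in an ADME assay on MOLT-3 cells (Homo sapiens) for cytotoxicity, with a stated time of 7 days (on this read-out higher numbers stand for lower toxicity in this test and lower numbers for higher toxicity in this test), compound 2 gives > 20000 nM, which is a limit of the assay and not a number.
Compound 3, `Nc1nc2c(ncn2/C=C2/CC2(CO)CO)c(=O)[nH]1`: in this assay compound 3 gives > 20000 nM, again a limit rather than a number.
Compound 1, `Nc1nc(NC2CCCCC2)c2ncn(/C=C3/CC3(CO)CO)c2n1`: in this assay compound 1 gives "not determined" (no result reported), that is, no result was reported for compound 1.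

Within the data shown here, compound 2 therefore stands only at a limit, and the one other compound with a result sits at the same limit, so no ordering among the measured compounds can be drawn; this is summed up by the limit of > 20000 nM in this assay, at which 2 of the 3 values shown sit. Among the measured compounds shown here, no pair of measured compounds differs in a single place, so no measured step is available.

Compound 4, `COCCOc1nc(N)nc2c1ncn2/C=C1/CC1(CO)CO`, is not yet measured. It differs from compound 2 in one place: 2-methoxyethoxy in place of butylamino on an aromatic carbon.

With both recorded values resting at the limit, the step from compound 2 to compound 4 in this assay is expected to be none beyond the scatter, which is what a number no higher from compound 2 to compound 4 (the limit leaves the size open) means here. For compound 4 the estimated value in this assay is 20000 nM, with a range from 8000 nM to 50000 nM, and most likely the assay would again report only a limit.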

Compound 4, half-maximal cytotoxic concentration: > 20000 nM
Compound 4 was reported as a limit (the forecaster's own chance of this, stated with the estimate: 85%); the middle value sits exactly at the limit.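

Compound 2 and compound 4 both stand only at a limit in this assay, so no step between them can be read: the limit of > 20000 nM in this assay, at which 3 of the 4 values shown sit.

The compounds shown leave open at what concentration any of them would become cytotoxic, and whether 2-methoxyethoxy in place of butylamino changes that concentration.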